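Enlarging the Ether Substituent on Compound 3

The source may report more compounds than this note shows. Statements on the series, on what has been measured and on what is new or still open speak of the compounds shown alone.

Of the compounds shown here, three have been measured in an assay for inhibition of serine/threonine-protein kinase Sgk1 (Homo sapiens), with stated times of 30 min and 60 min, in the presence of a further agent that is not named here; a higher number here means a weaker inhibitor, a lower number a stronger inhibitor. Compound 1 `O=C(N[C@@H]1CCNC1)c1cc(-c2ccc(NS(=O)(=O)c3cccc(Cl)c3Cl)cc2)nc2[nH]ncc12` gives < 1 nM in this assay, and this is a limit of the assay rather than a number (the limit of < 1 nM in this assay, at which 1 of the 3 values shown sits). Going by the values given here, compound 2 `O=C(NC1CCN(C2CC2)C1)c1cc(-c2ccc(NS(=O)(=O)c3cccc(Cl)c3Cl)cc2)nc2[nH]ncc12` gives 6 nM in this assay, and the step of an at least 6.0-fold higher number from compound 1 to compound 2 (0.77 log units; beyond the scatter) is the only change at a single place for which two readings exist. Compound 3 `Cc1n[nH]c2nc(-c3ccc(NS(=O)(=O)c4cc(Cl)ccc4F)cc3)nc(OC3CCOCC3)c12` gives 5 nM in this assay, the lowest of the two numbers shown, with compound 2 as its nearest neighbour and within the scatter of it.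

Compound 4 `Cc1n[nH]c2nc(-c3ccc(NS(=O)(=O)c4cc(Cl)ccc4F)cc3)nc(OC3CC(C)(C)N(C)C(C)(C)C3)c12` has not yet been measured. It differs from compound 3 in one place: 1,2,2,6,6-pentamethylpiperidin-4-yl in place of oxan-4-yl on an oxygen on an aromatic ring. Among the compounds with values here, the one measured step concerns a different position and a different kind of substituent, so it does not bear directly on this change; it only shows that adding a group on a ring nitrogen can move the number beyond the scatter. For compound 4 the author therefore expects a step of about a 1.8-fold higher number from compound 3 to compound 4 (0.26 log units; within the scatter), a modest weakening at most. The estimate for compound 4 in this assay is 9 nM, with a range from 2 nM to 40 nM.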

Compound 4, half-maximal inhibitory concentration: 2 nM
For compound 4 the middle estimate is 4.5-fold (0.65 log units) above the measured one; the measured number falls inside the stated range.
By their numbers in this assay, from the lowest: compound 4; then compounds 3 and 2 (each within the scatter of the next). At a limit, below all of these: compound 1.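

The earlier compounds shown here gave no reading at this position, and the first one shows that it accepts a much larger group without any loss in this assay: a 2.5-fold lower number from compound 3 to compound 4 (0.40 log units; beyond the scatter). Going by these compounds alone, the step goes the opposite way from the one earlier step, and it replaces oxan-4-yl by 1,2,2,6,6-pentamethylpiperidin-4-yl, so the larger group on the oxygen on an aromatic ring gives the lower number. The step is modest, and it covers the exchange of the ring oxygen for a ring nitrogen together with the added methyl groups, so it cannot be assigned to either one; nothing available here accounts for it.

The compounds shown leave open which part of the new group carries the step, a question that the simple piperidin-4-yl, 1-methylpiperidin-4-yl and 2,2,6,6-tetramethylpiperidin-4-yl groups would divide between the ring nitrogen and its methyl groups. They also leave open whether the position would accept an open-chain amine or a carboxylic acid in place of a ring.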